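The source may hold more compounds than are shown below. What is called first, only, known or untested is meant among the compounds shown, and "the series" means these compounds.

Measured compounds:
compound 1 `CCS(=O)(=O)n1cc2c(n1)CN([C@H]1CO[C@H](c3cc(F)ccc3F)[C@@H](N)C1)C2`: 5.2 h
compound 2 `CC(C)S(=O)(=O)n1cc2c(n1)CN([C@H]1CO[C@H](c3cc(F)ccc3F)[C@@H](N)C1)C2`: 1.3 h
compound 3 `CS(=O)(=O)Nc1n[nH]c2c1CN([C@H]1CO[C@H](c3cc(F)ccc3F)[C@@H](N)C1)C2`: 2 h

In an ADME assay on the whole organism for metabolic stability, with Rattus norvegicus as the target (on this read-out higher numbers stand for a longer-lived compound and lower numbers for a shorter-lived compound), compound 1 gives 5.2 h and compound 2 gives 1.3 h; the step between them, a 4.0-fold lower number from compound 1 to compound 2 (0.60 log units; beyond the scatter), is methyl in place of hydrogen on a saturated chain carbon bound to a saturated chain carbon and a sulfonyl sulfur. Within the data shown here, compound 3 gives 2 h in this assay; the difference between its core and the core of compound 1 is not broken down here, so the values show only that compound 3 stands lower than compound 1 beyond the scatter, while its gap to compound 2 is within the scatter.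

Compound 4 `CCS(=O)(=O)Nc1n[nH]c2c1CN([C@H]1CO[C@H](c3cc(F)ccc3F)[C@@H](N)C1)C2` is not yet measured and differs from compound 3 by methyl in place of hydrogen on a saturated chain carbon bound to a sulfonyl sulfur. This is the same kind of change as from compound 1 to compound 2, not the same: there the carbon taking the methyl is bound to a saturated chain carbon and a sulfonyl sulfur, here only to a sulfonyl sulfur.

Among the measured compounds shown here, the one precedent, a 4.0-fold lower number from compound 1 to compound 2 (0.60 log units; beyond the scatter), points to a lower number for compound 4, and the expected step in this assay is a 2.0-fold lower number from compound 3 to compound 4 (0.30 log units; within the scatter). A smaller step is assumed; the place differs and the cores differ. Compound 4 is estimated at 1 h, expected between 0.4 h and 2.5 h.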

Compound 4, half-life: 2.1 h
Beside the measured number, compound 4's estimate is 2.1-fold (0.32 log units) below it; the measured number falls inside the stated range.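

In this assay, the change from methylsulfonyl to ethylsulfonyl gives a 1.1-fold higher number from compound 3 to compound 4 (0.02 log units; within the scatter), so this change leaves the half-life on the core of compound 3 within the scatter. The change does not carry over in size from one core to the other: the same change on two cores in this assay, a 4.0-fold lower number (0.60 log units; beyond the scatter) from compound 1 to compound 2 and a 1.1-fold higher number (0.02 log units; within the scatter) from compound 3 to compound 4, 4.2-fold (0.62 log units) apart, beyond the scatter of two such steps. These two steps do not tell whether the core or the place accounts for the gap, as the added methyl sits on a saturated chain carbon bound to a saturated chain carbon and a sulfonyl sulfur in compound 2, but on a saturated chain carbon bound to a sulfonyl sulfur in compound 4.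

As far as these compounds go, it remains open whether an isopropylsulfonyl group on the core of compound 3 would match the half-life of compound 3 or repeat the step seen on the core of compound 1. From the compounds shown here alone, a longer chain such as propylsulfonyl, or a cyclopropylsulfonyl group, in place of ethylsulfonyl is also open on either core.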